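A few compounds are considered here, and "the series" means these few. Any claim that something is new, unique, unknown or untested is made for them only; others in the source may bear on it.

Measured compounds:
- compound 1 `O=C(/N=C(/NC(=O)c1cc(-c2ccccc2)nc2ccccc12)[Se]Cc1ccccc1)c1cc(-c2ccccc2)nc2ccccc12`: 88900 nM
- compound 2 `O=C(/N=C(/NC(=O)c1cccs1)[Se]Cc1ccccc1)c1cccs1`: 87400 nM

Both numbers come from a functional assay on K562 cells (Homo sapiens) for cytotoxicity, read by MTT assay, with a stated time of 72 h (a lower number here means that less compound is tolerated, a higher number that more compound is tolerated), which reports the concentration that kills half of the cells. Among these two numbers compound 1 is nominally the larger, but its gap to compound 2 lies within the scatter, so no real order between the two can be claimed; the two cores, an aromatic bicyclic one and a thiophene one, give the same picture.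

Compound 3 `C[Se]/C(=N\C(=O)c1cc(-c2ccccc2)nc2ccccc12)NC(=O)c1cc(-c2ccccc2)nc2ccccc12` has not yet been measured. It differs from compound 1 only by hydrogen in place of phenyl on a saturated chain carbon bound to a selenium atom, so the change is benzyl to methyl on the selenium. Among the measured compounds shown here, no measured pair shows this kind of change, and nothing in the data points in a direction. The step from compound 1 to compound 3 in this assay, a 1.1-fold lower number from compound 1 to compound 3 (0.05 log units; within the scatter), is expected to stay within the scatter. Compound 3 is therefore estimated at 80000 nM, with a range from 30000 nM to 200000 nM.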

Compound 3, concentration lethal to 50% of the cells: 73100 nM
For compound 3 the middle estimate is 1.1-fold (0.04 log units) above the measured one; the measured number falls inside the stated range.
By their numbers in this assay, from the lowest: compounds 3, 2 and 1 (each within the scatter of the next).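

In this assay the change from benzyl to methyl on the selenium gives a 1.2-fold lower number from compound 1 to compound 3 (0.08 log units; within the scatter) and so no difference that can be told apart from repeat-measurement noise. Among the compounds shown here, this is the first pair that differs at this position alone, and it shows that the whole phenyl, with its six carbons and aromatic ring, can leave this saturated chain carbon bound to a selenium atom without a clear shift in this read-out. No supporting measurement here explains this result.

Still open, as far as these compounds go, is whether another group on the selenium, such as a longer chain like butyl or a chain ending in an amine or a carboxylic acid, would move the number beyond the scatter. From the compounds shown here alone, it is also open whether benzyl to methyl would read the same on the core of compound 2.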